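A few compounds are considered here, and "the series" means these few. Any claim that something is new, unique, unknown or untested is made for them only; others in the source may bear on it.

Compound 1 `COc1ccc(C(=O)/C(=C/c2ccc([N+](=O)[O-])cc2)CCOC(C)=O)cc1` and compound 2 `COc1ccc(C(=O)/C(=C/c2ccc([N+](=O)[O-])cc2)CC(C)C)cc1` share a core and differ on a saturated chain carbon bound to a double-bonded chain carbon. In a functional assay on A549 cells (Homo sapiens) for inhibition, read by XTT assay, with a stated time of 48 h (a lower number here means a stronger inhibitor, a higher number a weaker inhibitor), compound 1 gives only a limit of the assay, > 100000 nM. In this assay compound 2 likewise gives only a limit, > 100000 nM. The step that the two limits leave unreadable from compound 1 to compound 2 is therefore unreadable, since (the limit of > 100000 nM in this assay, at which 2 of the 2 values shown sit). Compound 3 `CCN(CC)C/C(=C\c1ccc([N+](=O)[O-])cc1)C(=O)c1ccc(OC)cc1` carries diethylamino in place of isopropyl on a saturated chain carbon bound to a double-bonded chain carbon. Among the measured compounds shown here, no measured step bears on this change. The step from compound 2 to compound 3 is expected to be an at least 1.6-fold lower number from compound 2 to compound 3 (0.22 log units; that floor lies within the scatter). Compound 3 is estimated at 60000 nM, between 8000 nM and 300000 nM.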

Compound 3, half-maximal inhibitory concentration: 22000 nM
Beside the measured number, compound 3's estimate is 2.7-fold (0.44 log units) above it; measured number inside the range.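

In this assay diethylamino on this saturated chain carbon gives an at least 4.5-fold lower number from compound 2 to compound 3 (0.65 log units; beyond the scatter) when it replaces isopropyl and an at least 4.5-fold lower number from compound 1 to compound 3 (0.65 log units; beyond the scatter) when it replaces acetoxymethyl, so this position can move the read-out, which the two earlier compounds could not show. Both steps give only a minimum size, not a full size, because the starting compounds sit at a limit: the limit of > 100000 nM in this assay, at which 2 of the 3 values shown sit.

The compounds shown leave open whether the nitrogen of diethylamino matters or only its added carbons. A smaller amine such as dimethylamino, a ring amine such as piperidine, or an all-carbon chain of matching length would help separate these.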